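A few compounds are considered here, and "the series" means these few. Any claim that something is new, unique, unknown or untested is made for them only; others in the source may bear on it.

Compound 1 `O=c1[nH]cnc2c1c(-c1ccoc1)cn2[C@@H]1O[C@H](CO)[C@@H](O)[C@H]1O` and compound 2 `O=c1[nH]cnc2c1c(-c1ccco1)cn2[C@@H]1O[C@H](CO)[C@@H](O)[C@H]1O` share one core and differ only in the aryl group attached to it. In a functional assay on HCT-116 cells (Homo sapiens), read by MTT assay, with a stated time of 72 h (on this read-out higher numbers stand for weaker inhibition and lower numbers for stronger inhibition), compound 1 gives 10300 nM. In this assay compound 2 gives 18300 nM. The change between them, (furan-2-yl in place of furan-3-yl on an aromatic carbon), produced a 1.8-fold higher number from compound 1 to compound 2 (0.25 log units; within the scatter), so the two values cannot be separated.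

Compound 3 `COc1nc(N)nc2c1c(-c1ccoc1)cn2[C@@H]1O[C@H](CO)[C@@H](O)[C@H]1O` carries a different core; the difference between the two cores is not broken down here. In this assay compound 3 reaches only the limit > 20000 nM, which is not a measured number but the edge of what the assay reports. This limit, (the limit of > 20000 nM in this assay, at which 1 of the 3 values shown sits), is where compound 3 sits, and it is one of the three values shown.

Compound 4 `COc1nc(N)nc2c1c(-c1ccco1)cn2[C@@H]1O[C@H](CO)[C@@H](O)[C@H]1O` is not yet measured. It stands to compound 3 as compound 2 stands to compound 1: the change furan-2-yl in place of furan-3-yl on an aromatic carbon is the same change, on the same place, as that from compound 1 to compound 2. On the core of compound 1 this change made a step within the scatter, as shown by a 1.8-fold higher number from compound 1 to compound 2 (0.25 log units; within the scatter). Compound 4 is therefore expected to remain at or beyond the limit where compound 3 already sits, because compound 3 gives > 20000 nM and the earlier step of a 1.8-fold higher number from compound 1 to compound 2 (0.25 log units; within the scatter) points, if anywhere, toward a higher number. For compound 4 the expected step is a step that the limit leaves unreadable from compound 3 to compound 4. Compound 4 is estimated at 32000 nM, with a range from 18000 nM to 70000 nM, and most likely the assay will again return only a limit.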

Compound 4, half-maximal inhibitory concentration: > 20000 nM
Compound 4: a limit, no number (the forecaster's own chance of this, stated with the estimate: 85%); the middle value lies beyond the limit too.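

In this assay compound 4 returns only a limit, > 20000 nM, and not a number. Compound 3 stands at a limit as well, so no step between compound 3 and compound 4 can be read: the limit of > 20000 nM in this assay, at which 2 of the 4 values shown sit.

The compounds shown leave open whether furan-2-yl in place of furan-3-yl changes the read-out on the core of compound 3, and where the true values of compound 3 and compound 4 lie.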